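The source may report more compounds than this note shows. Statements on the series, on what has been measured and on what is new or still open speak of the compounds shown alone.

Measured so far in a functional assay (aorta) with Rattus norvegicus as the target; a higher number here means that more compound is needed for the effect, a lower number that less compound is needed:
- compound 1, `CCC(C)NC1=NS(=O)(=O)c2cccnc2N1`, 50.9 uM
- compound 2, `C[C@H](NC1=NS(=O)(=O)c2cccnc2N1)C1CCCCC1`, 29.2 uM
- compound 3, `C[C@@H](NC1=NS(=O)(=O)c2cccnc2N1)C1CCCCC1`, 25.2 uM

Compound 3 gives the lowest of the three numbers in this assay. Its nearest neighbour is compound 2, and the move a 1.2-fold lower number from compound 2 to compound 3 (0.06 log units; within the scatter) is within the scatter, so the two cannot be ordered. Among the measured compounds shown here, compound 1 sits furthest away; its value and that of compound 3 differ by more than the scatter, but the two structures differ in more than one place, so no single step is drawn between them.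

Compound 4, `C[C@@H](NC1=NS(=O)(=O)c2cccnc2N1)c1ccccc1`, is not yet measured. Relative to compound 3 the change is phenyl in place of cyclohexyl on a saturated chain carbon bound to an amine nitrogen and a saturated chain carbon. For the measured compounds named here, no measured step touches this kind of change: the only step on record, between compound 2 and compound 3, concerns configuration alone, and the fact that compounds 2 and 3 differ only in the configuration as drawn means it says nothing about the ring that is swapped here. The change in this assay is therefore expected to be small, with no clear direction beyond the scatter, and the step of a 1.2-fold higher number from compound 3 to compound 4 (0.08 log units; within the scatter) is taken as the estimate.

Compound 4 is thus expected to give about 30 uM in this assay, with a range from 10 uM to 90 uM.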

Compound 4, concentration for half-maximal effect: 9.9 uM
The estimate for compound 4 lay 3.0-fold (0.48 log units) above the measured number; the measured number lies below the stated range.
By their numbers in this assay, from the lowest: compound 4; then compounds 3, 2 and 1 (each within the scatter of the next, the first and the last beyond it).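

In this assay, among the compounds shown here, the ring on the saturated chain carbon bound to an amine nitrogen and a saturated chain carbon is the first change at this position to move the number beyond the scatter: phenyl in place of cyclohexyl gives a 2.5-fold lower number from compound 3 to compound 4 (0.41 log units; beyond the scatter), whereas the earlier pair differing only in configuration could not be ordered. The two groups match in their count of heavy atoms, in hydrogen-bond donors and acceptors and in having no net charge, and the computed comparison separates them only as an aromatic and a non-aromatic six-membered ring of carbon. Nothing on hand bears on a cause for this step.

On these data alone, the configurational comparison a 1.2-fold lower number from compound 2 to compound 3 (0.06 log units; within the scatter) belongs to the cyclohexyl pair alone, so whether configuration at this carbon counts for as little with phenyl remains open. Also open, as far as these compounds go, is how the number responds to a pyridyl ring in place of phenyl, to a methoxy group or a chlorine on the phenyl ring, or to a longer chain between the ring and this carbon.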